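The source may report more compounds than this note shows. Statements on the series, on what has been measured and on what is new or still open speak of the compounds shown alone.

Compound 1 `Cc1cc(-c2c(C)nn(C)c2C)cnc1-c1nnc(N(C)Cc2ccc3nccn3c2)o1`: 6310 nM
Compound 2 `Cc1cc(-c2c(C)nn(C)c2C)cnc1-c1nnc(N(C)Cc2ccc3ncc(-c4cnn(CCN(C)C)c4)n3c2)o1`: 1000 nM

Two compounds share the same core and were tested in an assay on COS-7 cells for inhibition of tyrosine-protein kinase receptor UFO (Homo sapiens), read by ELISA, with a stated time of 1 h; a higher number here means a weaker inhibitor, a lower number a stronger inhibitor. Compound 1 gives 6310 nM. Among the measured compounds shown here, compound 2 gives 1000 nM, the lowest of the two numbers, and the single measured step, a 6.3-fold lower number from compound 1 to compound 2 (0.80 log units; beyond the scatter), shows that adding the 1-(2-(dimethylamino)ethyl)-1H-pyrazol-4-yl group makes a modest difference.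

Compound 3 `Cc1cc(-c2c(C)nn(C)c2C)cnc1-c1nnc(N(C)Cc2ccc3ncc(-c4cccc(CN(C)C)c4)n3c2)o1` has not yet been measured. It differs from compound 2 in one place: 3-((dimethylamino)methyl)phenyl in place of 1-(2-(dimethylamino)ethyl)-1H-pyrazol-4-yl on an aromatic carbon. No measured step compares these two groups against each other; the only step shown, from hydrogen to the pyrazolyl group, says that a substituent of this kind at this position helps, but not whether a phenyl ring carrying the same amine would do as much. Because compound 2 gives 1000 nM, compound 3 is expected to land near it, with a step of a 1.2-fold higher number from compound 2 to compound 3 (0.08 log units; within the scatter). The estimate for compound 3 is 1200 nM, with a range from 350 nM to 4500 nM.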

Compound 3, half-maximal inhibitory concentration: 316 nM
Estimate against measurement, compound 3: 3.8-fold (0.58 log units) above; measured number outside the range, below it.
By their numbers in this assay, from the lowest: compound 3; then compound 2; then compound 1.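

In this assay, the two substituents are not interchangeable on this aromatic carbon: replacing the 1-(2-(dimethylamino)ethyl)-1H-pyrazol-4-yl group with 3-((dimethylamino)methyl)phenyl gives a 3.2-fold lower number from compound 2 to compound 3 (0.50 log units; beyond the scatter). Both groups end in the same dimethylamino unit, so that unit alone does not set the number; what carries it also counts. Measured against hydrogen at the same place, the phenyl group gives a 20-fold lower number from compound 1 to compound 3 (1.30 log units; beyond the scatter), the largest step among these compounds.

The swap changes the ring and the link to the amine together, so the compounds shown cannot separate the two, and a plain phenyl ring without the amine, or a phenyl ring carrying a morpholine instead, remains an open comparison. Nothing available here explains why the two groups differ.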